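The compounds below may be only part of what the source reports. "The series", "measured", "known", "first", "only" and "open" are said of these compounds alone.

Measured in a physicochemical assay for lipophilicity; on this read-out lower numbers stand for lower lipophilicity and higher numbers for higher lipophilicity:

Compound 1 `COc1c(OC)c(OC(=O)C(C)C)c2ccccc2c1OC(=O)C(C)C`: 4.61
Compound 2 `COc1c(OC)c(OC(C)=O)c2c(Cl)cccc2c1OC(C)=O`: 3.16

Compound 2, at 3.16, is the lower of the two values, and compound 1, at 4.61, stands above it by a gap beyond the usual scatter. Compound 3 `COc1c(OC)c(OC(C)=O)c2c(Sc3ccccc3)cccc2c1OC(C)=O` has not yet been measured. It carries phenylsulfanyl in place of chloro on an aromatic carbon of the shared core (phenylsulfanyl in place of chloro on an aromatic carbon). Within the data shown here, no measured pair differs in one place only, so the expectation rests on the structural change alone. A single atom leaves and a whole aromatic ring enters, and a rise in this assay beyond the scatter is expected. The estimated change is a number 1.54 log units higher from compound 2 to compound 3 (beyond the scatter). For compound 3 the expected value is 4.7, with an estimated range of 4.1 to 5.3.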

Compound 3, partition coefficient: 4.2
Beside the measured number, compound 3's estimate is 0.50 log units above it; low and high end bracket the measured number.
By their numbers in this assay, from the lowest: compound 2; then compound 3; then compound 1.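

In this assay, the aromatic carbon that carries chloro in compound 2 takes phenylsulfanyl instead, and the read-out shows a number 1.04 log units higher from compound 2 to compound 3 (beyond the scatter). Among these compounds, this is the first pair here that differs in one place only, so a change at this position can now be tied to a measured step, whereas the gap between compound 1 and compound 2 could not be assigned to any single change. The step shows that this position tolerates the swap of a single atom for a group holding an aromatic ring, but nothing at hand explains its size.

From the compounds shown here alone, how much of the step belongs to the sulfur and how much to the ring stays open, as a methylsulfanyl group or a phenyl group joined directly to the core would separate the two. Also open, going by these compounds, is how an amine at this position would read.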